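The source may report more compounds than this note shows. Statements on the series, on what has been measured and on what is new or still open speak of the compounds shown alone.

Measured so far in a functional assay for inhibition; a higher number here means a weaker inhibitor, a lower number a stronger inhibitor:
- compound 1 `CC(C)(C)c1cc(-c2cc(=O)c3ccc(OCCO)cc3o2)cc(C(C)(C)C)c1O`: 3000 nM
- compound 2 `CCOC(=O)COc1ccc2c(=O)cc(-c3cc(C(C)(C)C)c(O)c(C(C)(C)C)c3)oc2c1`: 3000 nM
- compound 3 `CCOC(=O)CCCCOc1ccc2c(=O)cc(-c3cc(C(C)(C)C)c(O)c(C(C)(C)C)c3)oc2c1`: 3000 nM

Compound 2 stands level with both neighbours on the numbers shown: the step of no change at the digits printed from compound 1 to compound 2 (within the scatter) and the step of no change at the digits printed from compound 2 to compound 3 (within the scatter) are within the scatter, and so is no change at the digits printed from compound 1 to compound 3 (within the scatter). None of the three separates from the others.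

Compound 4 `CCCCCCOc1ccc2c(=O)cc(-c3cc(C(C)(C)C)c(O)c(C(C)(C)C)c3)oc2c1` is not yet measured. It differs from compound 2 as follows: pentyl in place of ethoxycarbonyl on a saturated chain carbon bound to an oxygen on an aromatic ring. Among the measured compounds shown here, two measured steps bear on this change. Exchanging hydroxymethyl for ethoxycarbonyl on the saturated chain carbon bound to the aromatic oxygen gave no change at the digits printed from compound 1 to compound 2 (within the scatter), and lengthening the chain there gave no change at the digits printed from compound 2 to compound 3 (within the scatter). Three different groups at that place have returned the same reading, so a pentyl there is also expected to give no step beyond the scatter; the step expected is no change at the digits printed from compound 2 to compound 4 (within the scatter). Compound 4 is therefore estimated at 3000 nM in this assay, within 1500 nM to 6000 nM.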

Compound 4, half-maximal inhibitory concentration: 5000 nM
Estimate against measurement, compound 4: 1.7-fold (0.22 log units) below; the range from low to high includes it.
By their numbers in this assay, from the lowest: compounds 1, 2, 3 and 4 (each within the scatter of the next).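

In this assay, pentyl in place of ethoxycarbonyl takes out the carbonyl and both hydrogen-bond acceptors of the leaving group, yet the result is a 1.7-fold higher number from compound 2 to compound 4 (0.22 log units; within the scatter) and thus no separation. The other two comparisons agree, with a 1.7-fold higher number from compound 3 to compound 4 (0.22 log units; within the scatter) and a 1.7-fold higher number from compound 1 to compound 4 (0.22 log units; within the scatter) both giving the same result, so across these four compounds an all-carbon chain on the aromatic oxygen does not separate from the chains carrying an ester or a hydroxy group. No measurement shown offers an explanation for these readings.

Among the compounds shown here, whether any group at this place can move the number beyond the scatter remains open, since no step here does so. A terminal amine, a carboxylic acid or a chain longer than hexyl would test this.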